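Cycloheptyl on compound 2: what to expect

The compounds below may be only part of what the source reports. "The series", "measured", "known", "first", "only" and "open" are said of these compounds alone.

Measured so far in a physicochemical assay for lipophilicity, at pH 7.4; a higher number here means a more lipophilic compound, a lower number a more polar compound:
Compound 1 `O=c1[nH]c(OC2CCCCC2)nc2cnccc12`: 3.7
Compound 2 `O=c1[nH]c(Oc2cn[nH]c2)nc2cnccc12`: -0.6

Of these two, compound 2 holds the lower number, at -0.6, while compound 1 stands at 3.7. Compound 3 `O=c1[nH]c(Oc2cnn(C3CCCCCC3)c2)nc2cnccc12` has not been measured yet. It departs from compound 2 in one place: cycloheptyl in place of hydrogen on an aromatic nitrogen. The cycloheptyl takes the place of hydrogen on an aromatic nitrogen of the five-membered aromatic ring with 2 nitrogen.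

Within the data shown here, only one measured step bears on this change, and it is a large one: a number 4.30 log units lower from compound 1 to compound 2 (beyond the scatter). In that step, 1H-pyrazol-4-yl came in place of cyclohexyl on an oxygen on an aromatic ring. Compound 3 keeps that five-membered ring and gains a carbon-only ring on it, so a large rise in this assay is expected, of broadly similar size. This rests on a single precedent at a different place on the molecule, so the range stays wide. The expected change is a number 3.60 log units higher from compound 2 to compound 3 (beyond the scatter). For compound 3 the estimated value is 3, with an expected range from 2.2 to 3.8.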

Compound 3, distribution coefficient: 2.9
Compound 3: middle estimate off by 0.10 log units, on the high side, within the range that was stated.
By their numbers in this assay, from the lowest: compound 2; then compound 3; then compound 1.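

With compound 3, the aromatic nitrogen of the five-membered aromatic ring with 2 nitrogen becomes a second place in the series where a single change moves the number in this assay by a large amount, with cycloheptyl in place of hydrogen giving a number 3.50 log units higher from compound 2 to compound 3 (beyond the scatter). Among these compounds, the only earlier step, a number 4.30 log units lower from compound 1 to compound 2 (beyond the scatter), lay at the group on the oxygen, so it said nothing about this nitrogen, and the two steps now show large changes at two different places and in opposite directions. Nothing on hand accounts for the size of the new step.

Cycloheptyl is the only group on this nitrogen among the compounds shown, so one step cannot say how the number in this assay depends on ring size or on the kind of group placed there. A cyclopentyl ring, a longer chain such as n-hexyl, or a cycloheptyl ring carrying an amine or a carboxylic acid could show whether the step scales with the carbon count or shifts once such a group is present.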